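A few compounds are considered here, and "the series" means these few. Any claim that something is new, unique, unknown or untested is made for them only; others in the source may bear on it.

Measured so far in a functional assay on the whole organism with Mus musculus as the target; a lower number here means that less compound is needed, a higher number that more compound is needed for the effect:
compound 1 `CCCCCCN1CCC[C@H]1CNC(=O)c1cc(S(N)(=O)=O)ccc1OC` gives > 100 mg/kg, a limit of the assay and not a number;
compound 2 `CCCCCCN1CCC[C@@H]1CNC(=O)c1cc(S(N)(=O)=O)ccc1OC` gives 28.2 mg/kg;
compound 3 `CCN1CCC[C@H]1CNC(=O)c1cc(S(N)(=O)=O)cc2c1O[C@@H](C)C2` gives 5.7 mg/kg.

Compound 3 has the lowest number of the two that were obtained, with compound 2 the nearest number and that of compound 3 lower beyond the scatter. Compound 4 `CCN1CCC[C@@H]1CNC(=O)c1cc(S(N)(=O)=O)cc2c1O[C@H](C)C2` is its mirror image: the two compounds have the same atoms and bonds and differ only in configuration as drawn: 2 of 2 stereo elements differ (all stereocentres are inverted: mirror images); a stereocentre at a saturated ring carbon is drawn S in compound 3 and R in compound 4; a stereocentre at a saturated ring carbon is drawn S in compound 3 and R in compound 4. Within the data shown here, one measured step bears on this: an at least 3.5-fold lower number from compound 1 to compound 2 (0.54 log units; beyond the scatter), where the one change was also an inversion at the saturated ring carbon from S to R (the fact that compounds 1 and 2 differ only in the configuration as drawn); the limit in compound 1 hides the true size (the limit of > 100 mg/kg in this assay, at which 1 of the 3 values shown sits). That precedent points toward a lower number for the R configuration, though it rests on a single pair with a longer chain and only one centre inverted. A step of a 1.9-fold lower number from compound 3 to compound 4 (0.28 log units; within the scatter) is therefore expected, with wide uncertainty. Compound 4 is estimated at 3 mg/kg, range 0.6 mg/kg to 40 mg/kg.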

Compound 4, dose for half-maximal effect: 145 mg/kg
Estimate against measurement, compound 4: 48-fold (1.68 log units) below, outside the stated range (above it).
By their numbers in this assay, from the lowest: compound 3; then compound 2; then compound 4.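

Inverting both stereocentres is far from neutral at this position, with a 25-fold higher number from compound 3 to compound 4 (1.41 log units; beyond the scatter), and this mirror-image pair shares everything else: the fact that compounds 3 and 4 differ only in the configuration as drawn

That direction is opposite to an at least 3.5-fold lower number from compound 1 to compound 2 (0.54 log units; beyond the scatter), so the effect of an S to R inversion at the saturated ring carbon does not carry over between the two pairs. Compound 1 gives > 100 mg/kg, a limit of the assay and not a number.

The compounds shown leave open which of the two stereocentres carries the step. From the compounds shown here alone, how a propyl chain in place of the ethyl would respond to the same inversion also stays open.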